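Thiophene-substituent change in the bicyclic amine series

The source may hold more compounds than are shown below. What is called first, only, known or untested is meant among the compounds shown, and "the series" means these compounds.

Measured compounds:
compound 1 `C[C@H]1[C@H](NCc2ccc(Cl)s2)C[C@H]2C[C@@H]1C2(C)C`: 25000 nM
compound 2 `C[C@H]1[C@H](NCc2sccc2-c2ccccc2)C[C@H]2C[C@@H]1C2(C)C`: 12500 nM
compound 3 `Cc1n[nH]cc1CN[C@@H]1C[C@H]2C[C@@H]([C@H]1C)C2(C)C`: > 100000 nM

In an ADME assay on MDCK cells (Canis lupus familiaris) for cytotoxicity, read by microscopy, with a stated time of 48 h (on this read-out lower numbers stand for higher toxicity in this test and higher numbers for lower toxicity in this test), compound 2 holds the lowest of the two numbers that are numbers; compound 1 sits with the nearest number, and the gap between compound 2 and compound 1 is within the scatter. For compound 3 the result is a limit of the assay and not a number, (the limit of > 100000 nM in this assay, at which 1 of the 3 values shown sits).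

Compound 4 `CCc1ccsc1CN[C@@H]1C[C@H]2C[C@@H]([C@H]1C)C2(C)C` differs from compound 2 in one place: ethyl in place of phenyl on an aromatic carbon.

For the measured compounds named here, the only measured step, an at least 4.0-fold higher number from compound 1 to compound 3 (0.60 log units; beyond the scatter), exchanges the whole aromatic ring on the saturated chain carbon bound to the amine nitrogen and so does not bear directly on a change of a substituent on the thiophene ring itself. The thiophene ring is kept in compound 4, and the ethyl group is small; the step from compound 2 to compound 4 in this assay is therefore expected to stay within the scatter, with a slight lean toward a higher number, a 1.6-fold higher number from compound 2 to compound 4 (0.20 log units; within the scatter).

For compound 4 a value of 20000 nM is estimated in this assay, within the range 8000 nM to 60000 nM.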

Compound 4, minimum cytotoxic concentration: 25000 nM
Estimate against measurement, compound 4: 1.3-fold (0.10 log units) below; the range from low to high includes it.
By their numbers in this assay, from the lowest: compounds 2, 1 and 4 (each within the scatter of the next). At a limit, above all of these: compound 3.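

For the compounds shown here, this is the first step in this assay that changes a substituent while the thiophene ring stays in place: ethyl in place of phenyl gives a 2.0-fold higher number from compound 2 to compound 4 (0.30 log units; within the scatter). At this aromatic carbon, two ring bonds from the ring sulfur, removing the six-membered aromatic ring therefore does not separate the two compounds on this test. Nothing measured here speaks to the reason for this reading.

Open, going by these compounds, is whether a carboxylic acid or an amine on this aromatic carbon would produce a step beyond the scatter. Equally open, on these data alone, is how a chain longer than ethyl, such as butyl, would read at the same place.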